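Removing an ethoxy group from a weakly cytotoxic thiourea

The source may report more compounds than this note shows. Statements on the series, on what has been measured and on what is new or still open speak of the compounds shown alone.

Compound 2 `CCOc1ccc2nc(NC(=S)Nc3ccccc3)sc2c1` is the only one of the three measured compounds to give a single number in a functional assay on U-937 cells (Homo sapiens) for cytotoxicity, read by MTT assay, with a stated time of 48 h; on this read-out higher numbers stand for weaker inhibition and lower numbers for stronger inhibition: in this assay compound 2 gives 37700 nM. Compound 1 `Fc1ccc2nc(Nc3nc4ccccc4s3)sc2c1` was tested twice, and in this assay compound 1 gives 40600 nM; 43500 nM (2 entries), two readings that sit within the usual scatter of each other (the several entries of compound 1 in this assay, 40600 nM; 43500 nM (2 entries)). Compound 3 `Cc1ccc2nc(Nc3nc4ccc(F)cc4s3)sc2c1` reaches only a limit of the assay, and in this assay compound 3 gives > 50000 nM. Compound 4 `S=C(Nc1ccccc1)Nc1nc2ccccc2s1` has not been measured; it differs from compound 2 by hydrogen in place of ethoxy on an aromatic carbon. Going by the values given here, with no measured step of this kind to lean on, the change is expected to shift the value by a 1.2-fold higher number from compound 2 to compound 4 (0.08 log units; within the scatter), a step that stays within the scatter. Compound 4 is therefore estimated at 45000 nM, with a likely range from 20000 nM to 100000 nM.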

Compound 4, half-maximal inhibitory concentration: > 50000 nM
Compound 4 ended at the assay's limit; the forecaster's own chance of this, stated with the estimate: 40%; at least 1.1-fold (0.04 log units) between middle value and limit.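

Going by these compounds alone, this is the first step in this assay between compounds that differ in one place, and hydrogen in place of ethoxy gives an at least 1.3-fold higher number from compound 2 to compound 4 (0.12 log units; that floor lies within the scatter). As far as these compounds go, the reading for compound 4 is a limit of the assay, so this step is only a floor and its full size stays unknown: the limit of > 50000 nM in this assay, at which 2 of the 4 values shown sit. Even so, it shows that this exchange on the aromatic carbon brings no stronger inhibition.

Still open, from the compounds shown here alone, is how an amine or a longer alkoxy chain at this place would read, and whether either would give a single number.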